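The compounds below may be only part of what the source reports. "The series", "measured", "known", "first", "only" and "open" are said of these compounds alone.

Measured so far: compound 1 `CC(C)(C)c1ccc(NC(=O)c2ccc(OC(F)(F)C(F)F)cc2)cc1` gives 70 nM in a functional assay on HEK293 cells for antagonist activity at transient receptor potential cation channel subfamily V member 1 (Homo sapiens), read by calcium flux; a higher number here means a weaker inhibitor, a lower number a stronger inhibitor; compound 2 `CC(C)(C)c1ccc(NC(=O)c2ccc(OC(F)(F)F)cc2)cc1` gives 120 nM in that assay.

Compound 2 holds the higher of these two numbers, with compound 1 its nearest neighbour at a distance that stays within the scatter. Among the compounds with values here, the only single-point step recorded so far, a 1.7-fold higher number from compound 1 to compound 2 (0.23 log units; within the scatter), changes a group on the oxygen-bound carbon and does not touch the oxygen itself.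

Compound 3 `CC(C)(C)c1ccc(NC(=O)c2ccc(SC(F)(F)F)cc2)cc1` has not been measured. Compared with compound 2, the change is (trifluoromethyl)sulfanyl in place of trifluoromethoxy on an aromatic carbon. Within the data shown here, no step among the measured compounds exchanges the oxygen for sulfur, so nothing here predicts the direction of this move. Among the measured compounds shown here, the one related step stayed within the scatter, and the same is expected for compound 3, whose step a 1.2-fold lower number from compound 2 to compound 3 (0.08 log units; within the scatter) is expected to be small. Compound 3 is therefore estimated at 100 nM, with a range from 40 nM to 250 nM.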

Compound 3, half-maximal inhibitory concentration: 253 nM
Compound 3: the middle estimate sits 2.5-fold (0.40 log units) below what was measured; the measured number lies above the stated range.
By their numbers in this assay, from the lowest: compounds 1 and 2 (each within the scatter of the next); then compound 3.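

In this assay, this position proves sensitive to the atom linking the fluorinated group to the ring: (trifluoromethyl)sulfanyl in place of trifluoromethoxy keeps the same heavy-atom count, yet gives a 2.1-fold higher number from compound 2 to compound 3 (0.32 log units; beyond the scatter), a modest change but the first here beyond the scatter. Measured against the 1,1,2,2-tetrafluoroethoxy group, the same sulfur-linked group gives a 3.6-fold higher number from compound 1 to compound 3 (0.56 log units; beyond the scatter), which makes compound 3 the weakest inhibitor of the three. No measurement available here explains why this exchange raises the number.

From the compounds shown here alone, it remains open whether the loss follows the sulfur link wherever it appears, which a longer chain on sulfur, such as 1,1,2,2-tetrafluoroethylsulfanyl, could test. Going by these compounds, it is also open how much the fluorine atoms matter at this position, which a plain methoxy or methylsulfanyl group could show.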